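The source may report more compounds than this note shows. Statements on the series, on what has been measured and on what is new or still open speak of the compounds shown alone.

Working notes on the series in a functional assay on microsomes from liver (Rattus norvegicus, strain Wistar) for inhibition, read by spectrophotometry, with a stated time of 60 min; a lower number here means a stronger inhibitor, a higher number a weaker inhibitor.

Compound 1 `COc1cc(C2CC(=NOC(=O)c3ccc(Cl)cc3)CC(c3ccc(O)c(OC)c3)N2C)ccc1O` gives 121000 nM in this assay. Going by the values given here, compound 2 `COc1cc(C2CC(=NOC(=O)c3ccc(O)cc3)CC(c3ccc(O)c(OC)c3)N2C)ccc1O` gives 22500 nM, the lowest of the two numbers so far; its nearest neighbour is compound 1, and the only step in the set is a 5.4-fold lower number from compound 1 to compound 2 (0.73 log units; beyond the scatter), which sets the direction for the position in question.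

Compound 3 `COc1cc(C2CC(=NOC(=O)c3ccc(F)cc3)CC(c3ccc(O)c(OC)c3)N2C)ccc1O` is not yet measured. Its change from compound 2 is fluoro in place of hydroxy on an aromatic carbon. The step from compound 1 to compound 2 bears on this directly, as it runs through the same position in the opposite sense, so a move back toward the number of compound 1 is expected, with a halogen again in place of hydroxy, though its size is uncertain with one step to go by. For compound 3 a step of a 3.1-fold higher number from compound 2 to compound 3 (0.49 log units; beyond the scatter) is expected. Compound 3 is therefore estimated at 70000 nM, within 25000 nM to 200000 nM.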

Compound 3, half-maximal inhibitory concentration: 140000 nM
For compound 3 the middle estimate is 2.0-fold (0.30 log units) below the measured one; the measured number falls inside the stated range.
By their numbers in this assay, from the lowest: compound 2; then compounds 1 and 3 (each within the scatter of the next).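

In this assay, fluoro behaves as chloro did at this position: replacing hydroxy on the aromatic carbon again gives a weaker inhibitor (a 6.2-fold higher number from compound 2 to compound 3 (0.79 log units; beyond the scatter)), while the two halogen compounds cannot be told apart (a 1.2-fold higher number from compound 1 to compound 3 (0.06 log units; within the scatter)). The earlier pair could not show whether its step reflected something particular to chloro, but with a second halogen the 4-hydroxyphenyl compound, compound 2, stands alone as the strongest inhibitor of the three. Nothing available explains this difference between hydroxy and the two halogens.

The compounds shown leave open whether the lower number belongs to hydroxy specifically or would also appear with an amine or a methoxy group at this place. They also leave open whether a hydroxy group on the same ring but elsewhere would give a comparable number.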